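The source may report more compounds than this note shows. Statements on the series, on what has been measured and on what is new or still open speak of the compounds shown alone.

In a functional assay on HepG2 cells (Homo sapiens) for antiproliferative activity, read by MTT assay, with a stated time of 72 h (a lower number here means a stronger inhibitor, a higher number a weaker inhibitor), compound 1 `COc1ccc(N2C(=O)COc3ccc(-c4cnc(Cl)c(NS(=O)(=O)c5ccc(F)cc5)c4)cc32)cc1` gives only a limit, > 40000 nM, and not a number. Compound 2 `O=C1COc2ccc(-c3cnc4ccccc4c3)cc2N1c1ccc(F)cc1` reads 37200 nM, and compound 3 `COc1ccc(N2C(=O)COc3ccc(-c4cnc(OC)c(NS(=O)(=O)c5ccc(F)cc5)c4)cc32)cc1` reads 13100 nM. Compound 4 `O=C1COc2ccc(-c3cnc(Cl)c(NS(=O)(=O)c4ccc(F)cc4)c3)cc2N1C1CC1` carries cyclopropyl in place of 4-methoxyphenyl on an amide-type nitrogen in a ring. Within the data shown here, the only measured step, an at least 3.0-fold lower number from compound 1 to compound 3 (0.48 log units; beyond the scatter), is methoxy in place of chloro on an aromatic carbon, so it leaves this nitrogen untouched and gives no direct size for the change. With the starting point only a limit, no clear move in either direction is expected. The expected change, an at least 1.1-fold lower number from compound 1 to compound 4 (0.05 log units; that floor lies within the scatter), stays within the scatter. Compound 4 is estimated at 35000 nM, with an expected range from 12000 nM to 70000 nM.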

Compound 4, half-maximal inhibitory concentration: 8510 nM
Beside the measured number, compound 4's estimate is 4.1-fold (0.61 log units) above it, outside the stated range (below it).
By their numbers in this assay, from the lowest: compounds 4 and 3 (each within the scatter of the next); then compound 2. At a limit, above all of these: compound 1.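

In this assay, changing the group on this amide-type nitrogen in a ring gives an at least 4.7-fold lower number from compound 1 to compound 4 (0.67 log units; beyond the scatter). Among these compounds, the earlier compounds showed only a change on an aromatic carbon, so this is the first sign that the group on this nitrogen also matters, and that a small cyclopropyl, with no aromatic ring, can take the place of 4-methoxyphenyl. The true size of the step remains unknown because compound 1 gives a limit and not a number: the limit of > 40000 nM in this assay, at which 1 of the 4 values shown sits.

The compounds shown leave open how a methyl, a longer alkyl chain or an amine-bearing chain on this nitrogen would read. They also leave open whether cyclopropyl and methoxy together would lower the number further.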